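The source may hold more compounds than are shown below. What is called first, only, known or untested is meant among the compounds shown, and "the series" means these compounds.

Compound 1 `Cc1cccc(Oc2ccnc(N3CCC[C@H]3C(=O)NCCCn3ccnc3)n2)c1` was tested in an assay on isolated protein for inhibition of Rho-associated protein kinase 2 (Homo sapiens), read by HTRF, tested at 10 uM (a higher number here means more inhibition at the concentration tested (going by the name of the read-out), a lower number less inhibition), and gave 0%. Compound 2 `Clc1ccc2sc(CN3CCN(c4ncnc5c4CN(Cc4ccccc4)CC5)CC3)cc2c1` gave 0% in this assay, level with compound 1 at the digits shown, so the two stand together as the lowest of the three numbers. Compound 3 `COC[C@@H]1CCCN1C(=O)[C@@H]1CCCN1c1nccc(Nc2ccccc2)n1` gave 3% in this assay, a number within the usual scatter of compound 1. Compound 4 `Cc1cccc(Oc2ccnc(N3CCC[C@H]3C(=O)NCc3cccnc3)n2)c1` has not yet been measured. It differs from compound 1 in one place: pyridin-3-yl in place of 2-(1H-imidazol-1-yl)ethyl on a saturated chain carbon bound to an amide-type nitrogen. For the measured compounds named here, no step between two measured compounds is available to set this change against, and all three measured numbers sit close to zero. In this assay the change is therefore expected to bring no step beyond the scatter, a number 2 percentage points higher from compound 1 to compound 4 (within the scatter). Compound 4 is estimated at 2% in this assay, within a range from -8% to 12%.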

Compound 4, a percentage reported as inhibition, at one concentration (the size of the read-out at that concentration, not a potency): 0%
Compound 4: middle estimate off by 2 percentage points, on the high side, and the stated range covers the measured number.
By their numbers in this assay, from the lowest: compounds 1, 2, 4 and 3 (each within the scatter of the next).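

In this assay, pyridin-3-yl in place of 2-(1H-imidazol-1-yl)ethyl on a saturated chain carbon bound to an amide-type nitrogen brings no change at the digits printed from compound 1 to compound 4 (within the scatter). This first step at this position shows that exchanging one aromatic ring for the other leaves the number at the bottom of the assay, so it cannot tell which group serves better. Nothing available explains why the two compounds read alike.

Open, as far as these compounds go, is whether an amine or a carboxylic acid at this place would give a number clearly above zero. Also open, from the compounds shown here alone, is whether a phenyl ring would do so.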